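The source may hold more compounds than are shown below. What is called first, only, known or untested is meant among the compounds shown, and "the series" means these compounds.

In a functional assay on the whole organism (strain Swiss albino) for inhibition, with Mus musculus as the target, in the writhing test, with stated times of 60 min and 15 min, at a dose of 100 mg/kg by the oral route (on this read-out lower numbers stand for less inhibition and higher numbers for more inhibition at the one dose given (going by the name of the read-out)), compound 2 `CCNC(=O)CC1CCc2cc(OC)c(OC)cc21` gives 23.6%, the highest of the two numbers measured, with compound 1 `CNC(=O)CC1CCc2cc(OC)c(OC)cc21` nearest at 21.2%, the two lying within the scatter of each other. Going by the values given here, the single measured step, a number 2.4 percentage points higher from compound 1 to compound 2 (within the scatter), was a small structural change and stayed within the scatter. Among the compounds with values here, compound 3 `COc1cc2c(cc1OC)C(CC(=O)N1CCOCC1)CC2` carries a larger change, (morpholin-4-yl in place of ethylamino on a carbonyl carbon), on which no measured step bears directly. The expected step of a number 0.4 percentage points higher from compound 2 to compound 3 (within the scatter) is therefore kept small and uncertain. For compound 3 the estimated inhibition is 24%, with a range from 8% to 42%.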

Compound 3, a percentage reported as inhibition, in the whole organism at one dose (the size of the read-out at that dose, not a potency): 23.6%
Beside the measured number, compound 3's estimate is 0.4 percentage points above it, and the stated range covers the measured number.
By their numbers in this assay, from the lowest: compounds 1, 2 and 3 (each within the scatter of the next).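

Swapping ethylamino for morpholin-4-yl on a carbonyl carbon gives no change at the digits printed from compound 2 to compound 3 (within the scatter) in this assay, and swapping methylamino for it gives a number 2.4 percentage points higher from compound 1 to compound 3 (within the scatter) in the same test. This position therefore accepts a six-membered ring with one hydrogen-bond donor fewer, and the read-out does not separate the compounds. No supporting data explain this result.

Going by these compounds, whether piperidin-1-yl, which lacks the ring oxygen, or a carboxylic acid on this carbonyl carbon would stand apart remains open. With one dose, these numbers also leave potency open.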